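The compounds below may be only part of what the source reports. "The series", "measured", "known", "first", "only" and "open" are said of these compounds alone.

Measured so far in an ADME assay on the whole organism with Oryza sativa as the target, tested at 0.1 uM; a lower number here means a stronger effect, a higher number a weaker effect of the compound at the concentration tested:
compound 1 `CCc1ccc(NC(=O)N[C@H](C)c2ccccc2)cc1` gives 95%;
compound 2 `CCCCc1ccc(NC(=O)N[C@H](C)c2ccccc2)cc1` gives 100%;
compound 3 `CCCCc1ccc(NC(=O)N[C@@H](C)c2ccccc2)cc1` gives 98%.

Compound 2 gives the highest of these three numbers, yet the step of a number 5 percentage points higher from compound 1 to compound 2 (within the scatter) and the step of a number 2 percentage points lower from compound 2 to compound 3 (within the scatter) are both within the scatter, so the three stand level. Compound 4 `C[C@@H](NC(=O)Nc1ccc(C(F)(F)F)cc1)c1ccccc1` differs from compound 2 by trifluoromethyl in place of butyl on an aromatic carbon. Of the measured steps, only a number 5 percentage points higher from compound 1 to compound 2 (within the scatter) alters the chain attached to an aromatic carbon, and it stayed within the scatter; the step of a number 2 percentage points lower from compound 2 to compound 3 (within the scatter) rests only on the fact that compounds 2 and 3 differ only in the configuration as drawn and is also within the scatter. Neither step points to a change beyond the scatter in this assay, although the group that enters is not a chain, so some slack is expected. Compound 4 is estimated at 93% (from 78% to 100%), a step of a number 7 percentage points lower from compound 2 to compound 4 (within the scatter) expected to stay within the scatter.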

Compound 4, a percentage reported as activity, at one concentration (the size of the read-out at that concentration, not a potency): 93%
Estimate against measurement, compound 4: no gap at the digits printed, and the stated range covers the measured number.
By their numbers in this assay, from the lowest: compounds 4, 1, 3 and 2 (each within the scatter of the next).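

Within the data shown here, at this place, on an aromatic carbon para to a large group, the earlier compounds carried only carbon chains, and trifluoromethyl, a group that is not a chain, now leaves the read-out in this assay level with them. Replacing butyl gives a number 7 percentage points lower from compound 2 to compound 4 (within the scatter), and replacing ethyl gives a number 2 percentage points lower from compound 1 to compound 4 (within the scatter). No measured property here bears on this change.

The compounds shown leave open whether an amine or a carboxylic acid at this place would bring a step beyond the scatter.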